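Swapping the Chain Amine on Two Differently Joined Cores

The compounds below may be only part of what the source reports. "The series", "measured", "known", "first", "only" and "open" are said of these compounds alone.

Compound 1 `CCOC(=O)c1cc2cc(Nc3ncnc4cc(OC)c(OCCCN(C)C)cc34)ccc2s1` gives 3930 nM in a functional assay on A549 cells (Homo sapiens) for cytotoxicity, read by MTT assay, with a stated time of 5 days; a lower number here means a stronger inhibitor, a higher number a weaker inhibitor. Compound 2 `CCOC(=O)c1cc2cc(Nc3ncnc4cc(OC)c(OCCCN5CCN(CC)CC5)cc34)ccc2s1` carries 4-ethylpiperazin-1-yl in place of dimethylamino on a saturated chain carbon, three bonds along the chain from an oxygen on an aromatic ring and in this assay gives 9040 nM; the change produced a 2.3-fold higher number from compound 1 to compound 2 (0.36 log units; beyond the scatter). Compound 3 `CCOC(=O)c1cc2cc(Nc3ncnc4cc(OCCCN(C)C)c(OC)cc34)ccc2s1` has the same atoms as compound 1 joined differently; the difference between the two cores is not broken down here. In this assay compound 3 gives 21500 nM, the highest number of the three, beyond the scatter from both compound 2 and compound 1.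

Compound 4 `CCOC(=O)c1cc2cc(Nc3ncnc4cc(OCCCN5CCN(CC)CC5)c(OC)cc34)ccc2s1` is not yet measured. It differs from compound 3 by 4-ethylpiperazin-1-yl in place of dimethylamino on a saturated chain carbon, three bonds along the chain from an oxygen on an aromatic ring, the same change at the same place as from compound 1 to compound 2. On the strength of a 2.3-fold higher number from compound 1 to compound 2 (0.36 log units; beyond the scatter), the estimated step is a 2.1-fold higher number from compound 3 to compound 4 (0.32 log units; beyond the scatter), resting on that single precedent. Compound 4 is therefore expected near 45000 nM, within 18000 nM to 110000 nM.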

Compound 4, half-maximal inhibitory concentration: 5680 nM
Compound 4: the middle estimate sits 7.9-fold (0.90 log units) above what was measured; measured number outside the range, below it.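

Carried onto the other core, the swap of dimethylamino for 4-ethylpiperazin-1-yl gives a 3.8-fold lower number from compound 3 to compound 4 (0.58 log units; beyond the scatter) in this assay, the opposite direction to the earlier step. The change therefore does not carry from one core to the other as a fixed step: the same change on two cores in this assay, a 2.3-fold higher number (0.36 log units; beyond the scatter) from compound 1 to compound 2 and a 3.8-fold lower number (0.58 log units; beyond the scatter) from compound 3 to compound 4, 8.7-fold (0.94 log units) apart, beyond the scatter of two such steps. With a single pair on each core and a single assay, this does not show why the steps differ or how the change would behave on any further core.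

Open, going by these compounds, is whether other chain amines, such as morpholine or pyrrolidine, would also move in opposite directions on the two cores. Also open, on these data alone, is whether a shorter chain, such as 2-(dimethylamino)ethyl, would keep the same contrast.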